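The compounds below may be only part of what the source reports. "The series", "measured", "known", "first", "only" and "open" are said of these compounds alone.

Compound 3 `Cc1noc(-c2nc(C)c3c(c2N)C(=O)N(Cc2ccc(F)cc2)C3=O)n1` is known in a physicochemical assay for solubility, using the shake flask method, in simulated intestinal fluid, measured as kinetic solubility, with a stated time of 2 h, at 25 degrees C, at pH 6.5 (on this read-out higher numbers stand for higher solubility and lower numbers for lower solubility), only by a limit, and compound 3 gives < 5000 nM. Compound 1 `Cc1nc(C#N)c(N)c2c1C(=O)N(Cc1ccccc1)C2=O` likewise sits at a limit, as compound 1 gives < 5000 nM in this assay. Two of the three values shown share this limit, as the limit of < 5000 nM in this assay, at which 2 of the 3 values shown sit, shows. Among the compounds with values here, compound 2 `Cc1nc(C(=O)O)c(N)c2c1C(=O)N(Cc1ccccc1)C2=O` gives 177000 nM in this assay, and the only measured step in this set is an at least 35-fold higher number from compound 1 to compound 2 (1.54 log units; beyond the scatter), a change of a different group on the shared core. Compound 4 `Cc1noc(-c2nc(C)c3c(c2N)C(=O)N(Cc2ccccc2F)C3=O)n1` differs from compound 3 by 2-fluorophenyl in place of 4-fluorophenyl on a saturated chain carbon bound to an amide-type nitrogen in a ring. Within the data shown here, since no measured step concerns this change, the expected step is a step that the limit leaves unreadable from compound 3 to compound 4, none beyond the scatter. Compound 4 is estimated at 3000 nM, with a range from 800 nM to 12000 nM, most likely again reported only as a limit.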

Compound 4, solubility: < 5000 nM
Compound 4 was reported as a limit (the forecaster's own chance of this, stated with the estimate: 70%); the middle value does not contradict the limit.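

In this assay no step can be read from compound 3 to compound 4, as both are reported only as limits: the limit of < 5000 nM in this assay, at which 3 of the 4 values shown sit. The compounds shown leave open whether 4-fluorobenzyl and 2-fluorobenzyl differ at all on this read-out.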